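Bicyclic amine variants on the quinoline core, hormone receptor binding

This account rests on a few compounds, and the source may have more. Where it says the series, first, only, none or still open, it means among the compounds named here.

Compound 1 `O=C(CCc1ccc(C(F)(F)F)cc1)Nc1ccc2nc(N3CC4CC3CN4)ccc2c1` is the reference point of the series. Among the compounds with values here, in an assay on isolated protein for displacement of a labelled ligand from melanin-concentrating hormone receptor 1 (Homo sapiens) (on this read-out lower numbers stand for stronger inhibition and higher numbers for weaker inhibition), compound 1 gives 210 nM, the second highest of the three numbers measured so far; its nearest neighbour is compound 2 `CCCN(CCC)c1ccc2cc(NC(=O)CCc3ccc(C(F)(F)F)cc3)ccc2n1` with 490 nM, and furthest from it lies compound 3 `CC(=O)NC1CCN(c2ccc3cc(NC(=O)CCc4ccc(C(F)(F)F)cc4)ccc3n2)C1` with 5 nM. The measured steps are a 2.3-fold higher number from compound 1 to compound 2 (0.37 log units; beyond the scatter) and a 42-fold lower number from compound 1 to compound 3 (1.62 log units; beyond the scatter); between the other two, a 98-fold lower number from compound 2 to compound 3 (1.99 log units; beyond the scatter).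

Compound 4 `O=C(CCc1ccc(C(F)(F)F)cc1)Nc1ccc2nc(N3CC4CC3CO4)ccc2c1` has not yet been measured in this assay. It differs from compound 1 in one place: a group of 7 heavy atoms (5 carbon, 1 nitrogen, 1 oxygen; 2 five-membered non-aromatic rings with 1 hetero atom each) in place of a group of 7 heavy atoms (5 carbon, 2 nitrogen; 2 five-membered non-aromatic rings with 1 hetero atom each), on an aromatic carbon. Within the data shown here, of the measured steps, the one from compound 1 to compound 2 bears most closely on it, as there the same group of 7 heavy atoms (5 carbon, 2 nitrogen; 2 five-membered non-aromatic rings with 1 hetero atom each) left the aromatic carbon and a group with no ring and one nitrogen entered, giving a 2.3-fold higher number from compound 1 to compound 2 (0.37 log units; beyond the scatter). The step to compound 3 introduced a different group with an acetamide and is less comparable. A modest weakening, or a change within the scatter, is therefore expected, amounting to a 1.7-fold higher number from compound 1 to compound 4 (0.22 log units; within the scatter). For compound 4 the estimated value in this assay is 350 nM, with a range from 150 nM to 900 nM.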

Compound 4, half-maximal inhibitory concentration: 13 nM
Estimate against measurement, compound 4: 27-fold (1.43 log units) above, and the stated range ends above it.
By their numbers in this assay, from the lowest: compound 3; then compound 4; then compound 1; then compound 2.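

In this assay, a swap on the aromatic carbon next to the ring nitrogen that keeps 7 heavy atoms and both five-membered rings, exchanging one nitrogen for oxygen and going from 1 hydrogen-bond donor to 0 hydrogen-bond donors, gives a 16-fold lower number from compound 1 to compound 4 (1.21 log units; beyond the scatter) and shows that this single hetero atom weighs heavily here. The two-ring framework therefore does not by itself hold the number up: the data show a 38-fold lower number from compound 2 to compound 4 (1.58 log units; beyond the scatter) and only a 2.6-fold higher number from compound 3 to compound 4 (0.41 log units; beyond the scatter) so an acetamide is not needed for a low number at this position. No measurement on hand accounts for the gain.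

Still open, from the compounds shown here alone, is whether the oxygen itself or the loss of the hydrogen on nitrogen drives the step. An N-methyl analogue of the group in compound 1 and an all-carbon bridge in place of the oxygen would separate the two.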